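Cyclohexyl for cyclopropyl on the sulfonamide nitrogen

A few compounds are considered here, and "the series" means these few. Any claim that something is new, unique, unknown or untested is made for them only; others in the source may bear on it.

Working notes on the bicyclic acid amide series. Compound 1 `O=C(Nc1ccc(S(=O)(=O)NC2CC2)cc1)C1C(C(=O)O)[C@H]2CC[C@@H]1O2` is the reference point. In a functional assay on HCT-8 cells (Homo sapiens) for cytotoxicity, read by MTT assay, with a stated time of 48 h (on this read-out lower numbers stand for stronger inhibition and higher numbers for weaker inhibition), compound 1 gives 28300 nM. Compound 2 `O=C(Nc1ccc(S(=O)(=O)N2CCN(c3ccc(F)cc3)CC2)cc1)C1C(C(=O)O)[C@H]2CC[C@@H]1O2` gives 16600 nM in this assay, and compound 1 therefore holds the highest of the two numbers, with compound 2 nearest and within the scatter of it, so no order between the two can be read. Compound 3 `CCOC(=O)Cc1csc(NC(=O)C2C(C(=O)O)[C@H]3CC[C@@H]2O3)n1` sits at a limit of this assay and not at a number, reported as > 100000 nM. One line of the series records (the limit of > 100000 nM in this assay, at which 1 of the 3 values shown sits).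

Compound 4 `O=C(Nc1ccc(S(=O)(=O)NC2CCCCC2)cc1)C1C(C(=O)O)[C@H]2CC[C@@H]1O2` has not been measured in this assay. Against compound 1 the counted difference is cyclohexyl in place of cyclopropyl on a sulfonamide nitrogen. For the measured compounds named here, no pair of measured compounds differs at this one place, so the size of the step has no measured precedent, and the only other sulfonamide variation, compound 2, lies within the scatter of compound 1. The step of a 1.4-fold lower number from compound 1 to compound 4 (0.15 log units; within the scatter) is therefore expected to be small, likely within the scatter, with a slight lean to a lower number. Compound 4 is expected to give 20000 nM, in a range from 8000 nM to 60000 nM.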

Compound 4, half-maximal inhibitory concentration: 31000 nM
Beside the measured number, compound 4's estimate is 1.6-fold (0.19 log units) below it; measured number inside the range.
By their numbers in this assay, from the lowest: compounds 2, 1 and 4 (each within the scatter of the next). At a limit, above all of these: compound 3.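

On the sulfonamide nitrogen, the change from cyclopropyl to cyclohexyl now has a measured size in this assay: a 1.1-fold higher number from compound 1 to compound 4 (0.04 log units; within the scatter). For the compounds shown here, this is the first pair of measured compounds that differ at this one place, and the change from a three-membered to a six-membered ring of carbon leaves the number within the scatter, so no order can be read between the two compounds. Compound 3 remains the only compound at a limit, which is a limit of the assay and not a number: the limit of > 100000 nM in this assay, at which 1 of the 4 values shown sits.

The compounds shown leave open whether any group on this sulfonamide nitrogen can move the number beyond the scatter, as the single step at this place is too small to show a direction. Also open, going by these compounds, is what an amine or a carboxylic acid carried on the cyclohexyl ring, or an open butyl chain in place of the ring, would do to the number on the same core.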